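The source may report more compounds than this note shows. Statements on the series, on what has been measured and on what is new or still open speak of the compounds shown alone.

Compound 3, whose structure is `COC(=O)[C@@]1(C)CC[C@@H]2C3=C1CC[C@@H](C)[C@]3(C)C[C@@H]1c3ccccc3N[C@H]21`, gives 39000 nM in a functional assay on A549 cells (Homo sapiens) for inhibition, read by sulforhodamine B assay, with a stated time of 48 h (on this read-out lower numbers stand for stronger inhibition of growth and higher numbers for weaker inhibition of growth), the highest of the three numbers recorded. Its nearest neighbour is compound 2, with structure `COC(=O)[C@@]1(C)CCC=C2[C@@H]1CC[C@@H](C)[C@]2(C)Cc1c[nH]c2c(Cl)cccc12`, which in this assay gives 22000 nM, a gap that lies within the scatter of repeated measurements. The furthest is compound 1, with structure `COC(=O)[C@@]1(C)CCC=C2[C@@H]1CC[C@@H](C)[C@]2(C)Cc1c[nH]c2ccc(OC)cc12`, which in this assay gives 2200 nM, a gap that lies beyond the scatter. No single change links these compounds, so the numbers show only how they stand side by side.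

Compound 4, with structure `COC(=O)[C@@]1(C)CC[C@@H]2C3=C1CC[C@@H](C)[C@]3(C)C[C@@H]1c3cc(OC)ccc3N[C@H]21`, differs from compound 3 by methoxy in place of hydrogen on an aromatic carbon. Among the measured compounds shown here, no measured pair shows the effect of this change on the core shared by compounds 3 and 4. The only guide is that compound 1, which also carries a methoxy on its aromatic ring, gives 2200 nM, the lowest number shown. A modest step toward stronger inhibition is therefore expected for compound 4, though its size is uncertain. The expected step of a 2.6-fold lower number from compound 3 to compound 4 (0.41 log units; beyond the scatter) leads to an estimate for compound 4 of 15000 nM, with a range from 5000 nM to 45000 nM.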

Compound 4, concentration for 50% growth inhibition: 22000 nM
Beside the measured number, compound 4's estimate is 1.5-fold (0.17 log units) below it, within the range that was stated.
By their numbers in this assay, from the lowest: compound 1; then compounds 2, 4 and 3 (each within the scatter of the next).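

Among the compounds shown here, this pair gives the only direct reading of methoxy in place of hydrogen on an aromatic carbon, at the place that is meta to a fused ring and para to a fused ring. In this assay the change gives a 1.8-fold lower number from compound 3 to compound 4 (0.25 log units; within the scatter), so on the core shared by compounds 3 and 4 its effect at this place cannot be told apart from the scatter of repeated measurements. Nothing shown accounts for the size of this step.

Going by these compounds, whether an amine or a carboxylic acid at this place, or a longer chain such as ethoxy, would move the number beyond the scatter stays open, as does the effect of methoxy on another carbon of this ring. For the compounds shown here, no pair shows this change on the core of compound 1, so whether it behaves the same way there cannot be read.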